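The compounds below may be only part of what the source reports. "The series", "measured", "known", "first", "only" and "open" are said of these compounds alone.

Of the compounds shown here, three sharing one core have been tested in an ADME assay on Raji cells (Homo sapiens) for cytotoxicity, read by luminescence, with a stated time of 72 h; a lower number here means that less compound is needed, a higher number that more compound is needed for the effect. Compound 1 `CCOC(=O)c1c(-c2cc(F)cc(OC)c2)[nH]c2cc(OC)ccc2c1=O` gives only a limit there, > 21500 nM. Compound 2 `CCOC(=O)c1c(-c2cccc(C)c2)[nH]c2cc(OC)ccc2c1=O` likewise gives only a limit, > 21500 nM. Compound 3 `C=Cc1cccc(-c2[nH]c3cc(OC)ccc3c(=O)c2C(=O)OCC)c1` also returns a limit, > 21500 nM. Because all three rest at the limit of > 21500 nM in this assay, at which 3 of the 3 values shown sit, none of the steps among them can be read: a step that the two limits leave unreadable from compound 1 to compound 2, a step that the two limits leave unreadable from compound 1 to compound 3 and a step that the two limits leave unreadable from compound 2 to compound 3 all stay hidden behind the two limits. Compound 3 therefore stands where every value shown stands, at the limit, with nothing to set it apart.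

Compound 4 `CCOC(=O)c1c(-c2cccc(F)c2)[nH]c2cc(OC)ccc2c1=O` differs from compound 3 in one place: fluoro in place of vinyl on an aromatic carbon. The measured steps that bear on this change, a step that the two limits leave unreadable from compound 1 to compound 3 and a step that the two limits leave unreadable from compound 2 to compound 3, both swap one group for another on an aromatic carbon and both are unreadable, so they give no size to carry over. Within the data shown here, the only guidance is that every change of this kind so far has left the value at the limit. The expectation is therefore that compound 4 behaves the same way, with an estimated step that the limit leaves unreadable from compound 3 to compound 4 that most likely amounts to nothing readable. Compound 4 is thus estimated at 30000 nM, within a range of 15000 nM to 80000 nM, and the most probable outcome is that it too is reported only as a limit.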

Compound 4, half-maximal effective concentration: > 21500 nM
Compound 4 was reported as a limit; the forecaster's own chance of this, stated with the estimate: 85%; the middle value lies beyond the limit too.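

Compound 4 also gives only a limit in this assay, so its steps from compound 1, compound 2 and compound 3 cannot be read, because all four compounds rest at the same limit: the limit of > 21500 nM in this assay, at which 4 of the 4 values shown sit.

The compounds shown leave open what concentration of each would reach the half-maximal effect, and whether swapping these groups changes that concentration at all.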